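Propyl to Phenyl on the Amide Nitrogen

The source may hold more compounds than are shown below. What is called first, only, known or untested is meant among the compounds shown, and "the series" means these compounds.

Compound 1 `C=CC1=C(C(=O)NCCCCC)C(c2ccc(Cl)c(Cl)c2)OC1`: in a functional assay on SW480 cells (Homo sapiens) for cytotoxicity, read by MTT assay, with a stated time of 24 h (a lower number here means a stronger inhibitor, a higher number a weaker inhibitor), compound 1 gives 27500 nM.
Compound 2 `C=CC1=C(C(=O)NCCC)C(c2ccc(Cl)c(Cl)c2)OC1`: in this assay compound 2 reaches only the limit > 100000 nM.
Compound 3 `C=CC1=C(C(=O)NC(C)(C)C)C(c2ccc(OC)cc2)OC1`: in this assay compound 3 reaches only the limit > 100000 nM.

Compound 2 therefore stands at the limit of this assay, a limit it shares with compound 3, in keeping with the limit of > 100000 nM in this assay, at which 2 of the 3 values shown sit. Compound 4 `C=CC1=C(C(=O)Nc2ccccc2)C(c2ccc(Cl)c(Cl)c2)OC1` carries phenyl in place of propyl on an amide-type nitrogen. Among the measured compounds shown here, one measured step bears on this change: an at least 3.6-fold higher number from compound 1 to compound 2 (0.56 log units; beyond the scatter). There the longer chain went with the lower number, and the phenyl entering compound 4 is the larger group by the count given, so a modest step toward a lower number is expected, an at least 2.0-fold lower number from compound 2 to compound 4 (0.30 log units; that floor lies within the scatter), though starting from a limit its size is uncertain. Compound 4 is estimated at 50000 nM, within a range from 15000 nM to 200000 nM.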

Compound 4, half-maximal inhibitory concentration: > 100000 nM
Compound 4 was reported as a limit (the forecaster's own chance of this, stated with the estimate: 40%); at least 2.0-fold (0.30 log units) between middle value and limit.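

Phenyl in place of pentyl on the amide-type nitrogen gives an at least 3.6-fold higher number from compound 1 to compound 4 (0.56 log units; beyond the scatter), so in this assay the larger phenyl group does not match the pentyl chain of compound 1. Compound 2 and compound 4 both stand only as limits, and the step between them cannot be read. Compound 1 alone has a value off the limit: the limit of > 100000 nM in this assay, at which 3 of the 4 values shown sit.

The compounds shown leave open whether a hexyl or octyl chain on this nitrogen would give a lower number than compound 1. They also leave open what a benzyl group there would give.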